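The source may report more compounds than this note shows. Statements on the series, on what has been measured and on what is new or still open speak of the compounds shown alone.

Of the compounds shown here, three built on a shared core have been measured in an ADME assay on the whole organism for inhibition, with Echinochloa crus-galli var. formosensis as the target, with a stated time of 4 days; on this read-out lower numbers stand for stronger inhibition and higher numbers for weaker inhibition. Compound 1 `CC[C@@H](C)Nc1nc(Cl)nc(N[C@@H](C)c2ccccc2)n1` gives 7410 nM, compound 2 `CC(C)N(c1nc(Cl)nc(N[C@H](C)c2ccccc2)n1)C(C)C` gives 6610 nM, and compound 3 `CCN(c1nc(Cl)nc(N[C@H](C)c2ccccc2)n1)C(C)C` gives 52500 nM. Compound 1 thus holds the second highest of the three numbers; its value and that of compound 2 lie within the scatter of each other, while compound 3 stands beyond the scatter on the higher side. For the measured compounds named here, the only step between measured compounds that differ in one place is a 7.9-fold higher number from compound 2 to compound 3 (0.90 log units; beyond the scatter). Compound 4 `CCNc1nc(Cl)nc(N[C@@H](C)c2ccccc2)n1` differs from compound 1 by hydrogen in place of ethyl on a saturated chain carbon bound to a nitrogen on an aromatic ring and a saturated chain carbon. Both changes remove a group from a saturated chain carbon bound to a nitrogen on an aromatic ring and a saturated chain carbon, and because of a 7.9-fold higher number from compound 2 to compound 3 (0.90 log units; beyond the scatter) a higher number is expected for compound 4 in this assay. Compound 4 is therefore expected at 35000 nM, with a range from 10000 nM to 120000 nM. The step expected in this assay is a 4.7-fold higher number from compound 1 to compound 4 (0.67 log units; beyond the scatter).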

Compound 4, half-maximal inhibitory concentration: 30900 nM
Estimate against measurement, compound 4: 1.1-fold (0.05 log units) above; the measured number falls inside the stated range.
By their numbers in this assay, from the lowest: compounds 2 and 1 (each within the scatter of the next); then compounds 4 and 3 (each within the scatter of the next).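

In this assay, cutting sec-butyl back to ethyl gives a 4.2-fold higher number from compound 1 to compound 4 (0.62 log units; beyond the scatter), so the loss of ethyl from this saturated chain carbon bound to a nitrogen on an aromatic ring and a saturated chain carbon weakens inhibition beyond the scatter. The earlier compounds showed such a loss only for methyl, in a 7.9-fold higher number from compound 2 to compound 3 (0.90 log units; beyond the scatter); both steps shown now run towards a higher number, and neither goes against that direction. Nothing given here accounts for why the number rises with this change.

The compounds shown leave open whether methyl in place of ethyl on this carbon would give a number close to that of compound 1 or of compound 4. They also leave open whether a longer chain or a cyclopentyl ring at this place would lower the number further.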